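Swapping fluoro for chloro on the benzylidene aryl ring

The source may report more compounds than this note shows. Statements on the series, on what has been measured and on what is new or still open speak of the compounds shown alone.

Of the compounds shown here, two built on a shared core have been tested in a functional assay on HuTu80 cells (Homo sapiens) for cytotoxicity, read by MTT assay, with a stated time of 72 h; on this read-out lower numbers stand for an effect already at smaller amounts and higher numbers for an effect only at larger amounts of compound. Compound 1, `O=C1/C(=C\c2ccc(F)cc2)c2ccccc2N1c1c(Cl)cccc1Cl`, carries a 4-fluorophenyl group on the exocyclic double bond, and in this assay compound 1 gives 8 ug/mL. Compound 2, `O=C1/C(=C\c2cccc(Oc3ccccc3)c2)c2ccccc2N1c1c(Cl)cccc1Cl`, bears a 3-phenoxyphenyl group in the same position, and in this assay compound 2 gives 10 ug/mL. Compound 1 thus stands at one end of the two numbers, but the pair lie within the usual scatter of each other, so no difference between them can be claimed.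

Compound 3, `O=C1/C(=C\c2ccc(Cl)cc2)c2ccccc2N1c1c(Cl)cccc1Cl`, has not yet been measured. It differs from compound 1 by chloro in place of fluoro on an aromatic carbon, a change that the data do not yet connect to any measured pair. Going by the values given here, with no step of this kind on record, and the two numbers so far close together, compound 3 is expected to stay near compound 1, with the step of a 1.1-fold lower number from compound 1 to compound 3 (0.06 log units; within the scatter) estimated to fall within the scatter. On that basis compound 3 is estimated at 7 ug/mL, with a range from 3.5 ug/mL to 14 ug/mL.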

Compound 3, concentration for half-maximal effect: 6 ug/mL
Estimate against measurement, compound 3: 1.2-fold (0.07 log units) above; measured number inside the range.
By their numbers in this assay, from the lowest: compounds 3, 1 and 2 (each within the scatter of the next).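

Going by these compounds alone, compound 1 and compound 3 form the first pair on record that differs in one place only, so this position now has a measured step where before it had none. In this assay that step is a 1.3-fold lower number from compound 1 to compound 3 (0.12 log units; within the scatter) and it shows that chloro and fluoro on this aromatic carbon, para to a large group, cannot be told apart in this read-out. The swap of 4-fluorophenyl for 4-chlorophenyl therefore gives no sign that the number depends on which of these two halogens is present, and nothing on record offers an explanation for this result.

The compounds shown leave open whether a group of a different kind on the same aromatic carbon, such as an amine, a carboxylic acid, a methoxy group or a longer alkyl chain, would produce a step beyond the scatter. They also leave open whether bromo or iodo at this place would stay as close to fluoro as chloro does, and whether the same swap would read alike on other cells.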